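The compounds below may be only part of what the source reports. "The series", "measured", "known", "first", "only" and "open" are said of these compounds alone.

Compound 1 `O=C(Nc1cc(-c2ccccc2)nn1-c1ccccc1)c1cccc(F)c1`: 65 nM
Compound 2 `O=C(Nc1cc(-c2ccccc2)nn1-c1ccccc1)c1ccccc1O`: > 10000 nM

Two measured compounds share one core and differ only in the group on the carbonyl carbon. In an assay on isolated protein with metabotropic glutamate receptor 5 (Rattus norvegicus) as the target (on this read-out lower numbers stand for an effect already at smaller amounts and higher numbers for an effect only at larger amounts of compound), compound 1 gives 65 nM. Compound 2 reaches only a limit of this assay, > 10000 nM, so for compound 2 nothing more than a bound is known; this is the limit of > 10000 nM in this assay, at which 1 of the 2 values shown sits. Within the data shown here, the one measured step, an at least 150-fold higher number from compound 1 to compound 2 (2.18 log units; beyond the scatter), is the only comparison available, and it places compound 2 at the weak end of what has been seen.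

Compound 3 `O=C(Nc1cc(-c2ccccc2)nn1-c1ccccc1)c1ccsc1` has not yet been measured. It differs from compound 2 by thiophen-3-yl in place of 2-hydroxyphenyl on a carbonyl carbon. Among the measured compounds shown here, the single measured step bears on this change in the opposite sense: the 2-hydroxyphenyl group that enters from compound 1 to compound 2 is the one that now leaves, while a new aromatic group takes its place. Compound 3 is therefore expected to move back toward the number of compound 1, by an estimated step of an at least 50-fold lower number from compound 2 to compound 3 (1.69 log units; beyond the scatter). For compound 3 the expected value in this assay is about 200 nM, within a range from 40 nM to 2500 nM.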

Compound 3, half-maximal effective concentration: 2900 nM
The estimate for compound 3 lay 15-fold (1.16 log units) below the measured number; measured number above the stated range.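

In this assay the group on the carbonyl carbon now gives three outcomes rather than two, and losing the 2-hydroxyphenyl group does not by itself restore the number of compound 1: thiophen-3-yl gives an at least 3.4-fold lower number from compound 2 to compound 3 (0.53 log units; beyond the scatter) and, set against the 3-fluorophenyl group, gives a 45-fold higher number from compound 1 to compound 3 (1.65 log units; beyond the scatter) as well. The weak end of the series is therefore not confined to the 2-hydroxyphenyl group, since an aromatic group with no hydrogen-bond donor also stays well on the weak side of compound 1, and among the three compounds only the 3-fluorophenyl group reaches the low numbers. The first of these steps gives only a bound on the gain, because compound 2 stands at a limit: the limit of > 10000 nM in this assay, at which 1 of the 3 values shown sits.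

From the compounds shown here alone, it remains open whether the number of compound 1 depends on the fluorine or on the six-membered ring, a question that an unsubstituted phenyl or a 3-chlorophenyl group would bear on. Also open, going by these compounds, is whether thiophen-2-yl or pyridin-3-yl would behave like thiophen-3-yl at this position.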